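Replacing thiophen-3-yl with naphthalen-2-yl on the shared core

The source may report more compounds than this note shows. Statements on the series, on what has been measured and on what is new or still open speak of the compounds shown alone.

Three measured compounds share one core and differ only in the group on a saturated ring carbon between two ring oxygen atoms. In a functional assay for inhibition, with Homo sapiens as the target (a lower number here means tighter binding, a higher number weaker binding), compound 3 `O=C(O)CC/C=C\CC1COC(c2ccsc2)OC1c1cccnc1` gives 1580 nM. Compound 2 `O=C(O)CC/C=C\CC1COC(c2ccc([N+](=O)[O-])cc2)OC1c1cccnc1` gives 933 nM, and the comparison shows a 1.7-fold higher number from compound 2 to compound 3 (0.23 log units; within the scatter). Compound 1 `N#Cc1ccccc1C1OCC(C/C=C\CCC(=O)O)C(c2cccnc2)O1` gives 245 nM, which leaves compound 3 close to compound 2 and well apart from compound 1.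

Compound 4 `O=C(O)CC/C=C\CC1COC(c2ccc3ccccc3c2)OC1c1cccnc1` keeps the core and changes one group, with naphthalen-2-yl in place of thiophen-3-yl on a saturated ring carbon. Among the measured compounds shown here, no measured compound carries naphthalen-2-yl, so the evidence is indirect. Changing the group at this place has given a 3.8-fold higher number from compound 1 to compound 2 (0.58 log units; beyond the scatter) and a 6.4-fold higher number from compound 1 to compound 3 (0.81 log units; beyond the scatter), so a change here can matter, but only modestly so far. The direction rests weakly on compound 1 at 245 nM, since compound 2 offers no clear shift from compound 3. A small move toward a lower number in this assay is therefore expected, and it may not clear the scatter. The expected change is a 2.0-fold lower number from compound 3 to compound 4 (0.30 log units; within the scatter). The estimate for compound 4 is 800 nM, within an expected range of 250 nM to 2500 nM.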

Compound 4, dissociation constant: 1780 nM
Beside the measured number, compound 4's estimate is 2.2-fold (0.35 log units) below it; the measured number falls inside the stated range.
By their numbers in this assay, from the lowest: compound 1; then compounds 2, 3 and 4 (each within the scatter of the next).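

In this assay, naphthalen-2-yl, with 10 heavy atoms in 2 six-membered aromatic rings, reads no differently from thiophen-3-yl, with 5 heavy atoms in one five-membered ring, at a 1.1-fold higher number from compound 3 to compound 4 (0.05 log units; within the scatter). This position therefore accepts a clear increase in the size of the group without a shift beyond the scatter, and the same holds against the 4-nitrophenyl group, at a 1.9-fold higher number from compound 2 to compound 4 (0.28 log units; within the scatter), so compounds 2, 3 and 4 form one group despite their different aryl rings, while only compound 1 stands apart, with a 7.3-fold higher number from compound 1 to compound 4 (0.86 log units; beyond the scatter) the widest step in the set, though still a modest one. No measurement here explains why these three groups read alike or why the 2-cyanophenyl group differs.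

The compounds shown leave open whether the nitrile itself or its place on the phenyl ring sets compound 1 apart, a question that a plain phenyl group or a 4-cyanophenyl group at this position could address. From the compounds shown here alone, it is also open whether another group on the 2-position of the phenyl ring, such as an amine or a methoxy group, would give a number like that of compound 1.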